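The compounds below may be only part of what the source reports. "The series", "measured", "known", "first", "only" and "open" are said of these compounds alone.

Measured in a functional assay on MCF7 cells (Homo sapiens) for inhibition, read by sulforhodamine B assay; a lower number here means a stronger inhibitor, a higher number a weaker inhibitor:
- compound 1 `O=C1C=C(N2CCC2)C(=O)c2c1nc1n2[C@H]2OC[C@@H](O)[C@H]2OC1`: > 16000 nM, a limit
- compound 2 `O=C1C=C(NC2CCCCC2)C(=O)c2c1nc1n2[C@H]2OC[C@@H](O)[C@H]2OC1`: > 8000 nM, a limit
- compound 3 `O=C1C=C(Nc2cccc(F)c2)C(=O)c2c1nc1n2[C@H]2OC[C@@H](O)[C@H]2OC1`: 5500 nM

Of these three compounds, only compound 3 has an actual number, 5500 nM. The other two reached only the limits of the assay, so the set gives no second number to compare it with.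

The next compound, compound 4 `COc1ccccc1NC1=CC(=O)c2nc3n(c2C1=O)[C@H]1OC[C@@H](O)[C@H]1OC3`, keeps the shared core and changes only the aromatic group on the amine: 2-methoxyphenyl in place of 3-fluorophenyl on an amine nitrogen. In words, it carries 2-methoxyphenyl in place of 3-fluorophenyl on an amine nitrogen.

Two measured steps lead into compound 3, and both bear on this change only indirectly. The first is an at least 2.9-fold lower number from compound 1 to compound 3 (0.46 log units; beyond the scatter). The second is an at least 1.4-fold lower number from compound 2 to compound 3 (0.16 log units; that floor lies within the scatter). Both rest on limits, and neither exchanges one phenyl group for another, so neither gives a size for this replacement. The best guide is therefore the value of compound 3 itself, 5500 nM, and no step beyond the scatter is expected in this assay, with no direction favoured.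

The expected change is a 1.1-fold higher number from compound 3 to compound 4 (0.04 log units; within the scatter). Compound 4 is estimated at 6000 nM, with an expected range of 2500 nM to 15000 nM.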

Compound 4, half-maximal inhibitory concentration: > 4000 nM
Compound 4 gave a limit, no number; the forecaster's own chance of this, stated with the estimate: 30%; the middle value is on the limit's open side.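

In this assay compound 4 gave only a limit, > 4000 nM. None of the steps to compound 4 from compound 1, compound 2 or compound 3 can be read. The compounds shown leave open how 2-methoxyphenyl compares with 3-fluorophenyl on the amine nitrogen, and what actual numbers compound 1, compound 2 and compound 4 would have.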